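The compounds below may be only part of what the source reports. "The series", "measured", "known", "first", "only" and "open" are said of these compounds alone.

Compound 1 `COc1cc(C(=O)c2cn(-c3cccc(C)c3)cc2-c2nccs2)cc(OC)c1OC`: 20 nM
Compound 2 `COc1cc(C(=O)c2cn(-c3ccc(C)cc3)cc2-c2ccoc2)cc(OC)c1OC`: 18 nM

Going by the values given here, in a functional assay on MCF7 cells (Homo sapiens) for inhibition, with a stated time of 96 h (a lower number here means a stronger inhibitor, a higher number a weaker inhibitor), compound 2 gives 18 nM, a number within the scatter of the one for compound 1, 20 nM. Compound 3 `COc1cc(C(=O)c2cn(-c3ccc(C)cc3)cc2-c2nccs2)cc(OC)c1OC` keeps the 4-methylphenyl group of compound 2 but has 1,3-thiazol-2-yl in place of furan-3-yl on an aromatic carbon. Among the compounds with values here, no measured step isolates this change. Compound 1, which also bears 1,3-thiazol-2-yl, gives 20 nM, so no shift beyond the scatter is expected in this assay. The expected step is a 1.1-fold higher number from compound 2 to compound 3 (0.05 log units; within the scatter). Compound 3 is estimated at 20 nM, with an expected range from 8 nM to 50 nM.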

Compound 3, half-maximal inhibitory concentration: 14 nM
Beside the measured number, compound 3's estimate is 1.4-fold (0.15 log units) above it; the range from low to high includes it.
By their numbers in this assay, from the lowest: compounds 3, 2 and 1 (each within the scatter of the next).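

In this assay, 1,3-thiazol-2-yl in place of furan-3-yl on an aromatic carbon gives a 1.3-fold lower number from compound 2 to compound 3 (0.11 log units; within the scatter), so with 4-methylphenyl held fixed, this position accepts either five-membered aromatic ring without a shift beyond the scatter. With 1,3-thiazol-2-yl held fixed, 4-methylphenyl in place of 3-methylphenyl on the aromatic nitrogen gives a 1.4-fold lower number from compound 1 to compound 3 (0.15 log units; within the scatter), so moving the methyl also leaves the number within the scatter. No measurement at hand speaks to a cause for either result. Going by these compounds, whether this carbon would tolerate an amine or a carboxylic acid remains open. So does the effect of a methoxy group in place of the methyl on the phenyl ring.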